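Cyano in place of isopropoxy on the shared core

The compounds below may be only part of what the source reports. "The series", "measured", "known", "first", "only" and "open" are said of these compounds alone.

Measured so far:
- compound 1 (`COc1cccc(C(O)(c2ccc(Cl)cc2)c2cccnc2)c1`) gives 85600 nM 
- compound 2 (`CC(C)Oc1ccc(C(O)(c2ccc(Cl)cc2)c2cccnc2)cc1`) gives 56600 nM 
- compound 3 (`CC(C)Oc1ccc(C(O)(c2ccc(C(F)(F)F)cc2)c2cccnc2)cc1`) gives 47600 nM 

All three values come from an ADME assay on L6 cells (Rattus norvegicus) for cytotoxicity, read by resazurin assay, with a stated time of 72 h (on this read-out lower numbers stand for stronger inhibition and higher numbers for weaker inhibition), and lie close together. Compound 3 stands within the scatter of both compound 1 and compound 2, so its place among the three carries no rank.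

The next compound is compound 4 (`N#Cc1ccc(C(O)(c2ccc(C(F)(F)F)cc2)c2cccnc2)cc1`), with cyano in place of isopropoxy on an aromatic carbon, para to a large group (cyano in place of isopropoxy on an aromatic carbon). For the measured compounds named here, only one measured step bears on it, and only indirectly (a 1.2-fold lower number from compound 2 to compound 3 (0.08 log units; within the scatter)). That step is trifluoromethyl in place of chloro, which lies within the scatter and leaves the isopropoxy group untouched. Going by the values given here, no measured compound carries cyano, and no measured step removes isopropoxy, so the data offer no direct guide to this exchange.

On so flat a set, no step beyond the scatter is expected in this assay, with only a tentative lean towards a higher number. The estimated step is small (a 1.5-fold higher number from compound 3 to compound 4 (0.17 log units; within the scatter)). For compound 4 the estimated value is 70000 nM (range 30000 nM to 150000 nM).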

Compound 4, half-maximal inhibitory concentration in the L6 assay: 76500 nM
For compound 4 the middle estimate is 1.1-fold (0.04 log units) below the measured one, within the range that was stated.
By their numbers in the L6 assay, from the lowest: compounds 3, 2, 4 and 1 (each within the scatter of the next).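

Cyano in place of isopropoxy, on an aromatic carbon para to a large group, is the first change at this position among the compounds shown. In the L6 assay it gives a 1.6-fold higher number from compound 3 to compound 4 (0.21 log units; within the scatter), so on this read-out the position accepts the exchange of isopropoxy for cyano without a step that can be told from the scatter. In a physicochemical assay for solubility, read by nephelometry, measured as kinetic solubility, at pH 6.5 (a higher number here means a more soluble compound, a lower number a less soluble compound), compound 3 gives 1.6 ug/mL and compound 4 gives 6.3 ug/mL in this pair. The same exchange does give a step beyond the scatter in the physicochemical assay, so this one pair separates the two read-outs, with only one of them moving clearly: the measured solubility of compound 3, 1.6 ug/mL, and of compound 4, 6.3 ug/mL, a 3.9-fold higher number (0.60 log units; beyond the scatter)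

As far as these compounds go, whether the difference in the physicochemical assay follows from the entry of cyano or from the loss of isopropoxy stays open, and a single pair cannot separate the two, nor show whether the same holds with chloro in place of trifluoromethyl elsewhere on the shared core. An amine, a carboxylic acid or a longer alkoxy chain on this aromatic carbon would show whether either the L6 assay or the physicochemical assay can be moved further from this position, or whether the flat picture in the L6 assay persists.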